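Carbamoyl for Carboxy on a Ketone and an Alcohol Core

The source may hold more compounds than are shown below. What is called first, only, known or untested is meant among the compounds shown, and "the series" means these compounds.

The study concerns four compounds assessed in an assay for inhibition of Fatty-acid amide hydrolase 1 (Rattus norvegicus); a lower number here means a stronger inhibitor, a higher number a weaker inhibitor. Compound 1 `O=C(O)c1ccc(-c2cnc(C(=O)CCc3ccc(-c4ccccc4)cc3)o2)nc1` gives 14 nM in this assay. Compound 2 `NC(=O)c1cccc(-c2cnc(C(=O)CCc3ccc(-c4ccccc4)cc3)o2)n1` gives 1.2 nM in this assay. Compound 3 `O=C(O)c1ccc(-c2cnc(C(O)CCc3ccc(-c4ccccc4)cc3)o2)nc1` gives 10000 nM in this assay, the highest of the three numbers. Compound 4 `NC(=O)c1cccc(-c2cnc(C(O)CCc3ccc(-c4ccccc4)cc3)o2)n1` is not yet measured.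

Compound 2 arises from compound 1 by one change, (6-carbamoylpyridin-2-yl in place of 5-carboxypyridin-2-yl on an aromatic carbon), and that change brought a 12-fold lower number from compound 1 to compound 2 (1.07 log units; beyond the scatter). Compound 4 arises from compound 3 by the same change, (6-carbamoylpyridin-2-yl in place of 5-carboxypyridin-2-yl on an aromatic carbon), at the same place: on an aromatic carbon of a five-membered aromatic ring with 1 nitrogen and 1 oxygen, next to the ring oxygen, two ring bonds from the ring nitrogen, two ring bonds from the ring atom that bears a large group. The difference between the cores of compound 1 and compound 3 is not broken down here; their values simply show compound 3 with a far higher number.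

Beside the earlier step, the step from compound 3 to compound 4 is expected to be smaller, a 6.7-fold lower number from compound 3 to compound 4 (0.82 log units; beyond the scatter), because the high number of compound 3 10000 nM leaves it uncertain how much of the gain carries over. Compound 4 is therefore estimated at 1500 nM in this assay, expected to lie between 300 nM and 10000 nM.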

Compound 4, inhibition constant: 20000 nM
The estimate for compound 4 lay 13-fold (1.12 log units) below the measured number; the whole stated range lies below it.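

In this assay, placing 6-carbamoylpyridin-2-yl where 5-carboxypyridin-2-yl stood on the core of compound 3 gave a 2.0-fold higher number from compound 3 to compound 4 (0.30 log units; within the scatter), so the clear gain seen on the core of compound 1 did not reappear. The effect of this change therefore did not carry from one core to the other, and the two steps differ by more than their scatter: the same change on two cores in this assay, a 12-fold lower number (1.07 log units; beyond the scatter) from compound 1 to compound 2 and a 2.0-fold higher number (0.30 log units; within the scatter) from compound 3 to compound 4, 23-fold (1.37 log units) apart, beyond the scatter of two such steps This rests on a single pair of steps, so it does not show why the two cores part ways, nor how the change would behave on any third core.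

The compounds shown leave open how much of each step belongs to the swap of carboxy for carbamoyl and how much to the different place of that group on the pyridine ring. They also leave open whether a nitrile or a methyl ester on that ring, or an amine in place of the alcohol, would follow compound 2 or compound 4.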